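Urea series: hydroxy to methoxy on the chlorophenyl ring

A few compounds are considered here, and "the series" means these few. Any claim that something is new, unique, unknown or untested is made for them only; others in the source may bear on it.

Measured so far:
Compound 1 `O=C(Nc1cccc(-n2cc(-c3ccncc3)c(-c3cc(O)cc(Cl)c3)n2)c1)Nc1ccc(Cl)c(Cl)c1` gives 91%.
Compound 2 `COc1cc(Cl)cc(-c2nn(-c3cccc(NC(=O)Nc4cc(C(F)(F)F)cc(C(F)(F)F)c4)c3)cc2-c2ccncc2)c1` gives 21%.

Both numbers come from a functional assay on MCF7 cells (Homo sapiens) for inhibition, read by sulforhodamine B assay, with a stated time of 48 h, tested at 1 uM; on this read-out higher numbers stand for a weaker effect at the one concentration tested and lower numbers for a stronger effect. In this assay, within the data shown here, compound 1 stands highest of the two numbers; its only neighbour, compound 2, reads far lower, a gap beyond the scatter. Among the measured compounds shown here, the two compounds differ in more than one place, so no single step between them can be read off; their values only show that the methoxy compound with the bis(trifluoromethyl) urea is much the stronger of the pair.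

Compound 3 `COc1cc(Cl)cc(-c2nn(-c3cccc(NC(=O)Nc4ccc(Cl)c(Cl)c4)c3)cc2-c2ccncc2)c1` is not yet measured. It arises from compound 1 by methyl in place of hydrogen on an oxygen on an aromatic ring: hydroxy to methoxy, 3-chloro-5-hydroxyphenyl becoming 3-chloro-5-methoxyphenyl, with the urea of compound 1 kept. Compound 3 therefore carries the methoxy group of compound 2 and the urea of compound 1. For the measured compounds named here, no measured step isolates this change, so its size is uncertain. A downward step is expected because compound 2 gives 21% with the methoxy in place, though part of that gap may belong to the urea. The expected step is a number 36 percentage points lower from compound 1 to compound 3 (beyond the scatter), a fall beyond the scatter. Compound 3 is estimated at 55%, between 20% and 90%.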

Compound 3, a percentage reported as activity, at one concentration (the size of the read-out at that concentration, not a potency): 83%
Compound 3: middle estimate off by 28 percentage points, on the low side, and the stated range covers the measured number.
By their numbers in this assay, from the lowest: compound 2; then compounds 3 and 1 (each within the scatter of the next).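

In this assay, methyl in place of hydrogen on an oxygen on an aromatic ring gives a number 8 percentage points lower from compound 1 to compound 3 (within the scatter) with the urea of compound 1 kept, so hydroxy and methoxy cannot be told apart on this urea at the one concentration tested. Compound 2 and compound 3 share the methoxy group and differ only in the urea: compound 3 reads 83% in this assay and compound 2 reads 21% in the same assay, so the methoxy group alone does not bring the low number, which among these compounds goes with the bis(trifluoromethyl) urea. Nothing measured on these compounds bears on why the change from hydroxy to methoxy reads as it does here.

Still open, on these data alone, is whether hydroxy and methoxy also read alike with the bis(trifluoromethyl) urea, which only the hydroxy partner of compound 2 could settle. Also open, as far as these compounds go, is how the same position would read with a longer chain on the oxygen, such as ethoxy, or with an amine in place of the hydroxy.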